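Aryl urea in place of cyclopentyl urea on a shared core

A few compounds are considered here, and "the series" means these few. Any claim that something is new, unique, unknown or untested is made for them only; others in the source may bear on it.

Compound 1 `O=C(Nc1cccc(CNc2nccnc2Cl)c1)NC1CCCC1` was tested in a functional assay on HepG2 cells (Homo sapiens) for antiproliferative activity, read by MTT assay, with a stated time of 48 h (on this read-out lower numbers stand for stronger inhibition and higher numbers for weaker inhibition), where compound 1 gives 18400 nM. Among the two measured compounds this is the highest number; its nearest neighbour, compound 2 `O=C(Nc1cccc(CNc2nccnc2Cl)c1)Nc1cccc(C(F)(F)F)c1`, gives 6210 nM, a gap that lies beyond the usual scatter. Compound 3 `Cc1ccc(NC(=O)Nc2cccc(CNc3nccnc3Cl)c2)cc1` has not yet been measured. Compared with compound 1, the change is 4-methylphenyl in place of cyclopentyl on an amide-type nitrogen. For the measured compounds named here, since no measured pair shows this particular change, the expectation rests on compound 2, which carries an aromatic ring on the same amide-type nitrogen and gives the lower number. The account therefore expects a step downward, beyond the scatter, of about a 2.3-fold lower number from compound 1 to compound 3 (0.36 log units; beyond the scatter) in this assay, because compound 2 already gives 6210 nM. For compound 3 the estimated value in this assay is 8000 nM, with a likely range from 3000 nM to 20000 nM.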

Compound 3, half-maximal inhibitory concentration: 11500 nM
For compound 3 the middle estimate is 1.4-fold (0.16 log units) below the measured one, within the range that was stated.
By their numbers in this assay, from the lowest: compounds 2, 3 and 1 (each within the scatter of the next, the first and the last beyond it).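

In this assay, 4-methylphenyl in place of cyclopentyl on an amide-type nitrogen gives a 1.6-fold lower number from compound 1 to compound 3 (0.20 log units; within the scatter). For the compounds shown here, this is the first direct reading of a change at this position, and it shows that exchanging this non-aromatic ring of carbon for this aromatic one does not, in this single pair, shift the number beyond the usual scatter. No measurement of any property of these groups bears on the result, so the data offer no explanation for it.

The compounds shown leave open whether an amine or a carboxylic acid on the aromatic ring of compound 3 would move the number beyond the scatter. They also leave open what a longer chain in place of the cyclopentyl of compound 1, on the same nitrogen, would do.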